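The compounds below may be only part of what the source reports. "The series", "measured", "known", "first", "only" and "open" are said of these compounds alone.

Compound 1 `Cc1cc(NC(=O)Cn2nnc(-c3ccccc3)n2)n(C2CCCCC2)n1` in an assay on HEK293 cells for activation of Kir3.1/Kir3.2 (Homo sapiens), read by thallium flux; a higher number here means that more compound is needed for the effect, a lower number that less compound is needed: 96 nM
Compound 2 `Cc1cc(NC(=O)Cn2nnc(-c3ccccc3)n2)n(C2CCC(F)(F)CC2)n1` in this assay: 84 nM
Compound 3 `Cc1cc(NC(=O)Cn2nnc(-c3ccccc3)n2)n(C2CCC(C)(C)CC2)n1`: not yet measured in this assay

Compound 2 stands alongside compound 1; the step of a 1.1-fold lower number from compound 1 to compound 2 (0.06 log units; within the scatter) lies within the scatter, so the two numbers cannot be told apart. Compound 3 differs from compound 2 by 4,4-dimethylcyclohexyl in place of 4,4-difluorocyclohexyl on an aromatic nitrogen. For the measured compounds named here, the one measured step at this position, a 1.1-fold lower number from compound 1 to compound 2 (0.06 log units; within the scatter), was within the scatter, and it is the only step bearing on the change. No step beyond the scatter is therefore expected in this assay. Compound 3 is estimated at 100 nM with a range of 40 nM to 250 nM. The expected step of a 1.2-fold higher number from compound 2 to compound 3 (0.08 log units; within the scatter) is thus estimated to stay within the scatter.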

Compound 3, half-maximal effective concentration: > 221 nM
Compound 3 was reported as a limit; the forecaster's own chance of this, stated with the estimate: 5%; middle value at least 2.2-fold (0.34 log units) from the limit.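

In this assay, cyclohexyl and 4,4-difluorocyclohexyl could not be told apart, but 4,4-dimethylcyclohexyl separates from both, with an at least 2.6-fold higher number from compound 2 to compound 3 (0.42 log units; beyond the scatter) and an at least 2.3-fold higher number from compound 1 to compound 3 (0.36 log units; beyond the scatter). This position therefore does respond to a change of group. Both steps are lower bounds, as compound 3 is reported only as a limit: the limit of > 221 nM in this assay, at which 1 of the 3 values shown sits.

Going by these compounds, how far compound 3 lies beyond that limit stays open. Also open, on these data alone, is whether a hydroxyl or an amine on the cyclohexyl ring would give a number close to that of compound 2.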